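Moving the Methyl Around the Phenyl Arm

This account rests on a few compounds, and the source may have more. Where it says the series, first, only, none or still open, it means among the compounds named here.

Compound 1 `CCC(C(=O)NCc1ccc(C(F)(F)F)nc1N1CCC(C)CC1)c1ccc(NS(C)(=O)=O)c(F)c1`: 1.6 nM
Compound 2 `CC1CCN(c2nc(C(F)(F)F)ccc2CNC(=O)C(c2ccc(NS(C)(=O)=O)c(F)c2)C2CCCCC2)CC1`: 31.1 nM
Compound 3 `Cc1ccccc1C(C(=O)NCc1ccc(C(F)(F)F)nc1N1CCC(C)CC1)c1ccc(NS(C)(=O)=O)c(F)c1`: 42.9 nM

The three measured compounds share one core and differ only in the group sitting on a saturated chain carbon bound to an aromatic carbon and a carbonyl carbon. In an assay on CHO cells for antagonist activity at transient receptor potential cation channel subfamily V member 1 (Homo sapiens), read by FLIPR (a higher number here means a weaker inhibitor, a lower number a stronger inhibitor), compound 3 stands at the highest of the three numbers, though its gap to compound 2 is small: a 1.4-fold higher number from compound 2 to compound 3 (0.14 log units; within the scatter). The large steps both start from compound 1, whose ethyl group is replaced by a larger ring: a 19-fold higher number from compound 1 to compound 2 (1.29 log units; beyond the scatter) and a 27-fold higher number from compound 1 to compound 3 (1.43 log units; beyond the scatter).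

Compound 4 `Cc1cccc(C(C(=O)NCc2ccc(C(F)(F)F)nc2N2CCC(C)CC2)c2ccc(NS(C)(=O)=O)c(F)c2)c1` keeps the same atoms as compound 3 but joins them differently: 3-methylphenyl in place of 2-methylphenyl on a saturated chain carbon bound to an aromatic carbon and a carbonyl carbon. Within the data shown here, no measured step moves a methyl from one ring position to another, so nothing speaks directly to this change. Among the measured compounds shown here, the one comparison among the two larger groups, a 1.4-fold higher number from compound 2 to compound 3 (0.14 log units; within the scatter), was within the scatter, suggesting that once a ring sits at this carbon, the exact ring matters little among the compounds seen. The step from compound 3 to compound 4 is therefore expected to be small, in either direction: a 1.1-fold lower number from compound 3 to compound 4 (0.03 log units; within the scatter). Compound 4 is estimated at 40 nM, with a likely range from 12 nM to 130 nM.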

Compound 4, inhibition constant: 0.1 nM
Compound 4: middle estimate off by 400-fold (2.60 log units), on the high side; measured number below the stated range.
By their numbers in this assay, from the lowest: compound 4; then compound 1; then compounds 2 and 3 (each within the scatter of the next).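

In this assay, moving the methyl around the phenyl ring at this carbon leaves the atoms and the counted features of the group unchanged, yet it gives a 430-fold lower number from compound 3 to compound 4 (2.63 log units; beyond the scatter) and so shows that the exact ring can matter a great deal here. The 3-methylphenyl group also outdoes both other groups at this saturated chain carbon, with a 310-fold lower number from compound 2 to compound 4 (2.49 log units; beyond the scatter) against cyclohexyl and a 16-fold lower number from compound 1 to compound 4 (1.20 log units; beyond the scatter) against ethyl, so a larger group at this carbon does not always cost activity, even though compound 2 and compound 3 both lost ground to compound 1. Nothing available here explains why the two methylphenyl groups part so sharply.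

The compounds shown leave open where a plain phenyl group with no methyl would fall, and so whether the 3-methylphenyl group gains activity or the 2-methylphenyl group loses it. They also leave open whether a methoxy group or a chlorine in place of that methyl would keep the low number of compound 4, or whether the effect belongs to the methyl alone.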